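Same Change on Two Cores in a Cell Tolerance Assay

This account rests on a few compounds, and the source may have more. Where it says the series, first, only, none or still open, it means among the compounds named here.

Compound 1 `C1=CC[C@]23CCC[C@@]2(C1)CNC3`: > 100000 nM
Compound 2 `N=C(N)N1C[C@@]23CC=CC[C@@]2(CCC3)C1`: > 100000 nM
Compound 3 `C1CC23CCCC2(C1)CNC3`: > 100000 nM

Each of these three values is a limit of the assay, not a number, in an ADME assay on MDCK cells (Canis lupus familiaris) for cytotoxicity, read by microscopy; a lower number here means that less compound is tolerated, a higher number that more compound is tolerated. Compound 2 carries, on the core of compound 1, the change (a group of 3 heavy atoms (1 carbon, 2 nitrogen; no ring) in place of a hydrogen atom, on an amine nitrogen in a ring). The step that the two limits leave unreadable from compound 1 to compound 2 cannot be read, because both compounds sit at the limit of > 100000 nM in this assay, at which 3 of the 3 values shown sit. How the core of compound 3 differs from the core of compound 1 is not broken down here. Compound 4 `N=C(N)N1CC23CCCC2(CCC3)C1` carries the same kind of change on compound 3, (a group of 3 heavy atoms (1 carbon, 2 nitrogen; no ring) in place of a hydrogen atom, on an amine nitrogen in a ring). Since compound 3 also sits at the limit of > 100000 nM in this assay, at which 3 of the 3 values shown sit, the step of a number no higher from compound 3 to compound 4 (the limit leaves the size open) is expected to be unreadable as well. For compound 4 in this assay a value of 100000 nM is estimated, between 50000 nM and 200000 nM.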

Compound 4, minimum cytotoxic concentration: 54000 nM
For compound 4 the middle estimate is 1.9-fold (0.27 log units) above the measured one; measured number inside the range.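

In this assay the change gives an at least 1.8-fold lower number from compound 3 to compound 4 (0.26 log units; that floor lies within the scatter) on the core of compound 3. That size is only a floor, so the true step may be larger, but what is printed does not set it apart from the scatter of repeated measurements. The matching step on the core of compound 1 cannot be read, so nothing shows whether the change behaves alike on the two cores, because compound 1 and compound 2 both sit at a limit: the limit of > 100000 nM in this assay, at which 3 of the 4 values shown sit.

Still open, on these data alone, is how a methyl or an acetyl group on the same amine nitrogen would compare with the hydrogen atom. Also open, as far as these compounds go, is whether any such group would give a step clearly beyond the scatter on either core.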